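From methylcarbamoyl to carboxy on a shared core

The source may report more compounds than this note shows. Statements on the series, on what has been measured and on what is new or still open speak of the compounds shown alone.

For the measured compounds named here, in a functional assay on MDA-MB-231 cells (Homo sapiens) for inhibition, read by sulforhodamine B assay, with a stated time of 72 h (on this read-out higher numbers stand for weaker inhibition of growth and lower numbers for stronger inhibition of growth), compound 1 (`CNC(=O)CCc1ccncc1-c1ccc2ccccc2c1`) gives 8980 nM and so stands level with compound 2 (`O=C(/C=C/c1ccncc1-c1ccc2ccccc2c1)N1CCOCC1`) at 8980 nM as the only other compound measured so far. Compound 3 (`O=C(O)CCc1ccncc1-c1ccc2ccccc2c1`) keeps the core of compound 1 and carries hydroxy in place of methylamino on a carbonyl carbon, which turns 2-(methylcarbamoyl)ethyl into 2-carboxyethyl. Going by the values given here, compound 1 and compound 2 differ in more than one place, so the data hold no measured step for this exchange, and their matching values offer no direct guide to it. The expectation therefore rests on the structural change alone and remains uncertain. In this assay a modest step toward weaker inhibition of growth is expected, only slightly beyond the usual scatter, with no change at all still possible. The estimated step is a 2.2-fold higher number from compound 1 to compound 3 (0.35 log units; beyond the scatter) on this reasoning. Compound 3 is expected at 20000 nM with an estimated range of 7000 nM to 60000 nM in this assay once it is measured.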

Compound 3, concentration for 50% growth inhibition: > 10000 nM
Compound 3: no number, only a limit; the forecaster's own chance of this, stated with the estimate: 20%; the middle value lies beyond the limit too.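

In this assay compound 3 gives > 10000 nM, which is a limit of the assay and not a number. Hydroxy in place of methylamino on a carbonyl carbon, the change that turns 2-(methylcarbamoyl)ethyl into 2-carboxyethyl, now has its first reading on the shared core, with an at least 1.1-fold higher number from compound 1 to compound 3 (0.04 log units; that floor lies within the scatter), so the change gives no sign of stronger inhibition of growth, yet it is not shown to weaken it beyond the scatter either. Only a lower bound can be given for this step, and its true size stays out of reach: the limit of > 10000 nM in this assay, at which 1 of the 3 values shown sits.

Going by these compounds, how far the step from methylamino to hydroxy really runs remains open, as does whether it would hold on the unsaturated linker that compound 2 carries. Also open, on these data alone, is how other groups on that carbonyl carbon, such as methoxy, dimethylamino or a primary amine, would read against compound 1 and compound 3, and whether a longer chain in place of the 2-carboxyethyl group would change the picture.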